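The compounds below may be only part of what the source reports. "The series", "measured", "known", "first", "only" and "open" are said of these compounds alone.

Three ureas on a shared core have been run in a functional assay on HCC827 cells (Homo sapiens) for inhibition, read by MTT assay, with a stated time of 48 h, tested at 10 uM; a higher number here means more inhibition at the concentration tested (going by the name of the read-out), a lower number less inhibition. Compound 1 `CCc1ccc(Nc2cc(NC(=O)Nc3cc(OC)cc(OC)c3)ncn2)cc1` gives 66.2%. Compound 2 `COc1cc(NC(=O)Nc2cc(Nc3cc(I)ccc3OC)ncn2)cc(OC)c1` gives 71%, and compound 3 `COc1cc(NC(=O)Nc2cc(Nc3cc(Br)ccc3OC)ncn2)cc(OC)c1` gives 76.3%. Compound 3 holds the highest of the three numbers: the two steps up to it read a number 5.3 percentage points higher from compound 2 to compound 3 (within the scatter) and a number 10.1 percentage points higher from compound 1 to compound 3 (beyond the scatter). Compound 4 `COc1cc(NC(=O)Nc2cc(Nc3ccc(OC)c(I)c3)ncn2)cc(OC)c1` is next, with the change (3-iodo-4-methoxyphenyl in place of 5-bromo-2-methoxyphenyl on a nitrogen on an aromatic ring).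

Among the compounds with values here, no measured step swaps the positions of the halogen and methoxy on that ring. The nearest guide is the halogen swap a number 5.3 percentage points higher from compound 2 to compound 3 (within the scatter), and the aryl replacement a number 4.8 percentage points higher from compound 1 to compound 2 (within the scatter), which shows iodo on that ring sitting close to compound 1. Taken together, the step to compound 4 is expected to stay within the scatter or to run slightly downward, as a number 6.3 percentage points lower from compound 3 to compound 4 (within the scatter). Compound 4 is therefore estimated at 70%, with a range from 58% to 82%.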

Compound 4, a percentage reported as inhibition, at one concentration (the size of the read-out at that concentration, not a potency): 61.7%
Compound 4: the middle estimate sits 8.3 percentage points above what was measured, within the range that was stated.
By their numbers in this assay, from the lowest: compounds 4, 1, 2 and 3 (each within the scatter of the next, the first and the last beyond it).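

In this assay, the position on the nitrogen responds to the aryl group beyond the scatter, with a number 14.6 percentage points lower from compound 3 to compound 4 (beyond the scatter). Within the data shown here, the other two steps, a number 9.3 percentage points lower from compound 2 to compound 4 (within the scatter) and a number 4.5 percentage points lower from compound 1 to compound 4 (within the scatter), do not separate 3-iodo-4-methoxyphenyl from 5-iodo-2-methoxyphenyl or from 4-ethylphenyl, so the only step beyond the scatter here is the one that changes both the halogen and the placement of the groups on the ring, and it cannot assign the loss to either change. Nothing available here accounts for this difference.

From the compounds shown here alone, it remains open whether bromo in place of iodo on the 3-iodo-4-methoxyphenyl ring would restore the number. Going by these compounds, it also remains open how an amine or a carboxylic acid in place of the halogen on that ring would read at this single concentration.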